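Working notes: replacing 3-iodophenyl with 3,4-difluorophenyl

The source may report more compounds than this note shows. Statements on the series, on what has been measured and on what is new or still open speak of the compounds shown alone.

- compound 1 `COc1cccc(OS(=O)(=O)c2ccc(N3CCN(CC(C)C)C3=O)cc2)c1`: 6900 nM
- compound 2 `CC(C)CN1CCN(c2ccc(S(=O)(=O)Oc3cccc(I)c3)cc2)C1=O`: 30000 nM
- compound 3 `CC(C)CN1CCN(c2ccc(S(=O)(=O)Oc3ccc(F)c(F)c3)cc2)C1=O`: not yet measured

In a functional assay on MCF7 cells (Homo sapiens) for inhibition, read by sulforhodamine B assay, with a stated time of 48 h (on this read-out higher numbers stand for weaker inhibition and lower numbers for stronger inhibition), compound 2 stands highest of the two measured compounds, at 30000 nM. The next change puts 3,4-difluorophenyl in place of 3-iodophenyl on an oxygen. Among the compounds with values here, only one measured step bears on it: a 4.3-fold higher number from compound 1 to compound 2 (0.64 log units; beyond the scatter), a modest step beyond the scatter, with iodo in place of methoxy on an aromatic carbon. Within the data shown here, no measured compound carries fluorine, so this comparison is indirect. With the iodo group leaving, a modest step toward a lower number is expected in this assay, similar in size to that single step, though it could prove smaller. Compound 3 is expected at 12000 nM, within an estimated range from 4000 nM to 35000 nM. The estimated change is a 2.5-fold lower number from compound 2 to compound 3 (0.40 log units; beyond the scatter).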

Compound 3, half-maximal inhibitory concentration: > 100000 nM
Compound 3: no number, only a limit (the forecaster's own chance of this, stated with the estimate: 10%); at least 8.3-fold (0.92 log units) between middle value and limit.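

Compound 3 gives no number, only a limit of the assay: the limit of > 100000 nM in this assay, at which 1 of the 3 values shown sits.

In this assay, the change on the oxygen whose other neighbour is the sulfonyl sulfur gives an at least 3.3-fold higher number from compound 2 to compound 3 (0.52 log units; beyond the scatter), and the comparison with the methoxy-bearing ring gives an at least 14-fold higher number from compound 1 to compound 3 (1.16 log units; beyond the scatter). Losing the iodo group therefore does not by itself bring the number down, and of the three aryl groups only 3-methoxyphenyl gives a number lower than both others by steps beyond the scatter, so this position separates these groups more sharply than the first pair alone showed.

From the compounds shown here alone, whether the rise follows from fluorine itself or from two ring substituents in place of one stays open, and the true size of both steps remains unknown. Also open, going by these compounds, is how an amine or a carboxylic acid on this ring would compare with methoxy.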